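Swapping Dihydroxyphenyl for Dimethoxyphenyl on a Shared Scaffold

The compounds below may be only part of what the source reports. "The series", "measured", "known", "first", "only" and "open" are said of these compounds alone.

Of the compounds shown here, three have so far been measured in a functional assay on HL-60 cells (Homo sapiens) for inhibition, read by CCK-8 assay, with a stated time of 48 h; a higher number here means a weaker inhibitor, a lower number a stronger inhibitor. Compound 3 `CC(C)c1ccc(Oc2ccc(O)c(O)c2)c(-c2ccsc2S(=O)(=O)NCCNC(=S)Nc2ccc([N+](=O)[O-])cc2)c1` gives 8800 nM, and compound 1 `COc1ccc(Oc2ccc(C(C)C)cc2-c2ccsc2S(=O)(=O)NCCNC(=S)Nc2ccc([N+](=O)[O-])cc2)cc1OC` gives 11200 nM. Compound 1 differs from compound 3 by 3,4-dimethoxyphenyl in place of 3,4-dihydroxyphenyl on an oxygen on an aromatic ring, and that change produced a 1.3-fold higher number from compound 3 to compound 1 (0.10 log units; within the scatter). Compound 2 `O=C(Nc1cccc([N+](=O)[O-])c1)N1CCN(S(=O)(=O)c2sccc2-c2ccccc2Oc2ccc(O)c(O)c2)CC1` gives 4500 nM in this assay ; its gap to compound 1 lies beyond the scatter, while its gap to compound 3 stays within it. The difference between the core of compound 2 and the core of compound 3 is not broken down here.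

Compound 4 `COc1ccc(Oc2ccccc2-c2ccsc2S(=O)(=O)N2CCN(C(=O)Nc3cccc([N+](=O)[O-])c3)CC2)cc1OC` has not yet been measured. It differs from compound 2 by 3,4-dimethoxyphenyl in place of 3,4-dihydroxyphenyl on an oxygen on an aromatic ring, which is the same change, at the same place, as that made from compound 3 to compound 1. The expectation for compound 4 is a step of a 1.3-fold higher number from compound 2 to compound 4 (0.11 log units; within the scatter), because a 1.3-fold higher number from compound 3 to compound 1 (0.10 log units; within the scatter) was within the scatter. Compound 4 is therefore estimated to give 5800 nM in this assay . Its value is expected to fall between 2500 nM and 14000 nM.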

Compound 4, half-maximal inhibitory concentration: > 50000 nM
Compound 4: a limit, no number; the forecaster's own chance of this, stated with the estimate: 5%; middle value at least 8.6-fold (0.93 log units) from the limit.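

In this assay, compound 4 carries a limit and not a number: the limit of > 50000 nM in this assay, at which 1 of the 4 values shown sits.

On the core of compound 2, 3,4-dimethoxyphenyl in place of 3,4-dihydroxyphenyl gives an at least 11-fold higher number from compound 2 to compound 4 (1.04 log units; beyond the scatter), so the result of this change on one core does not carry over to the other, as the two steps side by side show: the same change on two cores in this assay, a 1.3-fold higher number (0.10 log units; within the scatter) from compound 3 to compound 1 and an at least 11-fold higher number (1.04 log units; beyond the scatter) from compound 2 to compound 4, at least 8.7-fold (0.94 log units) apart, beyond the scatter of two such steps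

This does not show which feature of the cores accounts for the gap, and with a single pair on each core it supports no general rule for the series; the limit also leaves the full size of the new step unknown.

The compounds shown leave open which part of the core of compound 2 sets it apart from the core of compound 3. They also leave open how that core would respond to a phenyl ring carrying one hydroxyl and one methoxy group, or to 3,4-diaminophenyl at the same place.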